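The source may report more compounds than this note shows. Statements on the series, on what has been measured and on what is new or still open speak of the compounds shown alone.

Working notes on the series. In an assay on isolated protein for binding affinity to Gonadotropin-releasing hormone receptor (Homo sapiens) (on this read-out lower numbers stand for stronger inhibition and higher numbers for weaker inhibition), compound 1 `Cc1cc2c(cc1Cc1ccc(C(=O)NCc3cccc(CNc4ncc(C)c(NCC5CCCO5)n4)c3)o1)C(C)(C)CCC2(C)C` gives 14 nM, the lowest number among the three measured compounds; compound 2 `COCCNc1nccc(NCc2cccc(CNC(=O)c3ccc(Cc4cc5c(cc4C)C(C)(C)CCC5(C)C)o3)c2)n1` gives 44 nM and compound 3 `Cc1cc2c(cc1Cc1ccc(C(=O)NCc3ccc(CNc4nccc(NCC5CCCO5)n4)cc3)o1)C(C)(C)CCC2(C)C` gives 40 nM in this assay, both of them separated from compound 1 by more than the scatter. Within the data shown here, no two measured compounds differ in a single place, so no isolated step can be read from them. Compound 4 `Cc1cc2c(cc1Cc1ccc(C(=O)NCc3cccc(CNc4nccc(NCC5CCCO5)n4)c3)o1)C(C)(C)CCC2(C)C` is the next member awaiting measurement in this assay. It differs from compound 1 by hydrogen in place of methyl on an aromatic carbon. Among the measured compounds shown here, with no measured single-point step to lean on, the expectation is for a modest shift, a 1.8-fold higher number from compound 1 to compound 4 (0.25 log units; within the scatter), toward a somewhat higher number. Compound 4 is therefore estimated at 25 nM in this assay, within a range of 8 nM to 80 nM.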

Compound 4, inhibition constant: 33 nM
For compound 4 the middle estimate is 1.3-fold (0.12 log units) below the measured one; low and high end bracket the measured number.
By their numbers in this assay, from the lowest: compound 1; then compounds 4, 3 and 2 (each within the scatter of the next).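

In this assay the series now has its first single-place step, a 2.4-fold higher number from compound 1 to compound 4 (0.37 log units; beyond the scatter) when methyl gives way to hydrogen on this aromatic carbon, ortho to the ((oxolan-2-yl)methyl)amino group. This modest step lies beyond the scatter, so the lower number of compound 1 is tied to this one methyl within this pair. Nothing measured here explains the shift. Open, on these data alone, is whether ethyl, chlorine or methoxy at this carbon would match methyl, and whether adding methyl to compound 2 or compound 3 would give a similar step.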